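A few compounds are considered here, and "the series" means these few. Any claim that something is new, unique, unknown or untested is made for them only; others in the source may bear on it.

Compound 1 `COc1ccc(-c2cc(N3CCC(CNS(N)(=O)=O)CC3)ncn2)cc1` and compound 2 `COc1ccccc1-c1cc(N2CCC(CNS(N)(=O)=O)CC2)ncn1` share one core and differ only in the aryl group. In a functional assay on M21 cells (Homo sapiens) for antiproliferative activity, read by sulforhodamine B assay, with a stated time of 48 h (a lower number here means a stronger inhibitor of growth, a higher number a weaker inhibitor of growth), compound 1 gives only a limit, > 100000 nM. In this assay compound 2 likewise gives only a limit, > 100000 nM. The step that the two limits leave unreadable from compound 1 to compound 2 therefore has no readable size. Compound 3 `NS(=O)(=O)NCC1CCN(c2cc(-c3ccccc3F)ncn2)CC1` differs from compound 2 by fluoro in place of methoxy on an aromatic carbon. Going by the values given here, the only measured step offers no size to transfer; what is known is the limit of > 100000 nM in this assay, at which 2 of the 2 values shown sit. For compound 3 the step of a number no higher from compound 2 to compound 3 (the limit leaves the size open) is expected to stay within scatter. The estimate for compound 3 in this assay is 100000 nM, between 30000 nM and 300000 nM.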

Compound 3, concentration for 50% growth inhibition: > 100000 nM
Compound 3 gave a limit, no number (the forecaster's own chance of this, stated with the estimate: 80%); the middle value sits exactly at the limit.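

Going by these compounds alone, compound 3 gives only a limit, > 100000 nM, and no step linking compound 1, compound 2 and compound 3 can be read. As far as these compounds go, whether any aryl group on the shared core gives a readable value in this assay stays open.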